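Fluorinated Tail on a Leukotriene Receptor Antagonist

A few compounds are considered here, and "the series" means these few. Any claim that something is new, unique, unknown or untested is made for them only; others in the source may bear on it.

Measured compounds:
Compound 1, `Cc1c(CCCC(=O)O)c2cccc(/C=C/c3ccc(OCCCCc4ccccc4)cc3)c2n1CC(=O)O`: 4.1 nM
Compound 2, `Cc1c(Cl)cccc1CCCCOc1ccc(C#Cc2cccc3c(CC(=O)O)c(C)n(CCCCC(=O)O)c23)cc1`: 65 nM

Both compounds were tested in a functional assay on CHO-K1 cells for antagonist activity at cysteinyl leukotriene receptor 1 (Homo sapiens), read by fluorescence and calcium flux, with stated times of 30 min and 1 h; on this read-out higher numbers stand for weaker inhibition and lower numbers for stronger inhibition. Compound 1 gives 4.1 nM, the lower of the two numbers and thus the stronger inhibitor; compound 2 gives 65 nM, a gap that lies beyond the usual scatter. The two structures differ in several places at once, so no single change can be read from that gap.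

Compound 3, `Cc1c(CCCC(=O)O)c2cccc(/C=C/c3ccc(OCCCCc4cc(F)c(F)c(F)c4F)cc3)c2n1CC(=O)O`, keeps the whole core of compound 1 and alters only the far end of the chain: 2,3,4,5-tetrafluorophenyl in place of phenyl on a saturated chain carbon, four bonds along the chain from an oxygen on an aromatic ring. Nothing measured here isolates this change, and compound 2 carries a different ring at that place together with other alterations, so it gives no clean guide. The expectation is a step no larger than the scatter, with compound 3 estimated at 6 nM (range 2 nM to 20 nM), meaning an expected step of a 1.5-fold higher number from compound 1 to compound 3 (0.17 log units; within the scatter).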

Compound 3, half-maximal inhibitory concentration in the cysteinyl leukotriene receptor 1 assay: 0.8 nM
Compound 3: middle estimate off by 7.5-fold (0.88 log units), on the high side; the whole stated range lies above it.
By their numbers in the cysteinyl leukotriene receptor 1 assay, from the lowest: compound 3; then compound 1; then compound 2.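

In the cysteinyl leukotriene receptor 1 assay, replacing phenyl with 2,3,4,5-tetrafluorophenyl at the far end of the chain gives a 5.1-fold lower number from compound 1 to compound 3 (0.71 log units; beyond the scatter), showing that this one change can shift the read-out on its own, which the earlier pair, differing in several places at once, could not reveal. In a physicochemical assay for permeability, using PAMPA, with a stated time of 4 h, at pH 7.4, tested at 50 uM (on this read-out higher numbers stand for higher permeability and lower numbers for lower permeability), the same change gives an at least 6.0-fold higher number from compound 1 to compound 3 (0.77 log units; beyond the scatter). In the physicochemical assay compound 3 gives 0.3 10^-6 cm/s as a measured number. In the physicochemical assay compound 1 gives < 0.05 10^-6 cm/s as a limit and not a true number: the limit of < 0.05 10^-6 cm/s in the physicochemical assay, at which 1 of the 2 values shown sits.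

Going by these compounds, it remains open whether all four fluorines are needed, or whether a simpler fluorophenyl group or a non-aromatic cyclohexyl group at this place would give a similar result. It is also unclear whether the same change would have a similar effect on a different core, such as that of compound 2.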